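Bromoalkyl chain length on the shared core

The source may hold more compounds than are shown below. What is called first, only, known or untested is meant among the compounds shown, and "the series" means these compounds.

Of the compounds shown here, three on the shared core have been measured. Compound 1 `COc1ccc(-c2coc3cc(OCCCSC(=S)N4CCN(Cc5ccccc5)CC4)ccc3c2=O)cc1` gives 25300 nM in a functional assay on ECa-109 cells for inhibition, with ECa-109 cell line (Homo sapiens) as the target, read by MTT assay, with a stated time of 48 h; on this read-out lower numbers stand for stronger inhibition and higher numbers for weaker inhibition. Compound 3 `COc1ccc(-c2coc3cc(OCCCSC(=S)N4CCN(C(C)=O)CC4)ccc3c2=O)cc1` gives 24700 nM; the step of a 1.0-fold lower number from compound 1 to compound 3 (0.01 log units; within the scatter) shows the end group on the ring nitrogen does little here. Compound 2 `COc1ccc(-c2coc3cc(OCCCCCBr)ccc3c2=O)cc1` gives 59100 nM, the highest number of the three, beyond the scatter from both compound 1 and compound 3.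

Compound 4 `COc1ccc(-c2coc3cc(OCCCBr)ccc3c2=O)cc1` is not yet measured. It differs from compound 2 by bromo in place of 2-bromoethyl on a saturated chain carbon, three bonds along the chain from an oxygen on an aromatic ring, the same change read further out as 5-bromopentyl to 3-bromopropyl. Among the compounds with values here, no measured step alters chain length alone: compound 1 and compound 3 differ from compound 2 in the terminal group as well, so they offer no clean comparison, and the one measured step concerns a different part of the molecule. Nothing therefore points to a step beyond the scatter; the expected step of a 1.2-fold lower number from compound 2 to compound 4 (0.07 log units; within the scatter) is small, with wide uncertainty. Compound 4 is estimated at 50000 nM, between 20000 nM and 130000 nM.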

Compound 4, half-maximal inhibitory concentration: 39700 nM
Beside the measured number, compound 4's estimate is 1.3-fold (0.10 log units) above it, within the range that was stated.
By their numbers in this assay, from the lowest: compounds 3, 1, 4 and 2 (each within the scatter of the next, the first and the last beyond it).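

Working from this assay, the step of a 1.5-fold lower number from compound 2 to compound 4 (0.17 log units; within the scatter) is the first in the series to alter chain length alone, with the terminal bromine kept, and it lies within the scatter. The change, 5-bromopentyl to 3-bromopropyl on the oxygen-linked chain, therefore does not separate these two compounds on this read-out, so across this pair the chain length shown carries no clear signal. No measurement on hand gives a reason for the size of this step.

Still open, going by these compounds, is whether a chain longer than 5-bromopentyl or shorter than 3-bromopropyl would give a step beyond the scatter. Also open, on these data alone, is what an amine or a carboxylic acid would do in place of the terminal bromine on the 3-bromopropyl chain.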